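Sulfonamide series: removing the amine methyl of compound 3

The source may report more compounds than this note shows. Statements on the series, on what has been measured and on what is new or still open speak of the compounds shown alone.

Of the compounds shown here, three on a shared core have been measured, varied at the amine end of the chain. Compound 1 `COc1ccc(CNCCCNS(=O)(=O)c2cc(C(F)(F)F)cc(C(F)(F)F)c2)cc1OC` gives 15000 nM in a functional assay on Capan-2 cells (Homo sapiens) for inhibition, read by MTT assay, with a stated time of 72 h; on this read-out higher numbers stand for weaker inhibition of growth and lower numbers for stronger inhibition of growth. Compound 2 `O=S(=O)(NCCCNCc1ccc(Cl)c(C(F)(F)F)c1)c1cc(C(F)(F)F)cc(C(F)(F)F)c1` gives 9100 nM in this assay. Going by the values given here, the one step measured so far, a 1.6-fold lower number from compound 1 to compound 2 (0.22 log units; within the scatter), exchanges the aryl group on the benzylic carbon and stays within the scatter. Compound 3 `CN(CCCNS(=O)(=O)c1cc(C(F)(F)F)cc(C(F)(F)F)c1)Cc1ccccc1` gives 46000 nM in this assay and stands highest of the three numbers: compound 1 is nearest, compound 2 furthest, and both gaps lie beyond the scatter.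

Compound 4 `O=S(=O)(NCCCNCc1ccccc1)c1cc(C(F)(F)F)cc(C(F)(F)F)c1` has not yet been measured. It differs from compound 3 by hydrogen in place of methyl on an amine nitrogen. Among the compounds with values here, no measured step touches this nitrogen; the single measured step changes the aryl group instead, so there is no direct precedent for the size of this change. What the numbers do show is that compound 1 and compound 2, which both carry hydrogen on that nitrogen, sit below compound 3, though they also carry a different aryl group, so the comparison is confounded. The expected step is therefore a modest one, a 2.3-fold lower number from compound 3 to compound 4 (0.36 log units; beyond the scatter), toward a lower number, with the direction not secure. The estimate for compound 4 in this assay is 20000 nM, with a range from 8000 nM to 50000 nM.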

Compound 4, concentration for 50% growth inhibition: 14000 nM
Beside the measured number, compound 4's estimate is 1.4-fold (0.15 log units) above it; measured number inside the range.
By their numbers in this assay, from the lowest: compounds 2, 4 and 1 (each within the scatter of the next); then compound 3.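

Hydrogen in place of methyl on the amine nitrogen is now measured on its own with the benzyl group unchanged, and in this assay it gives a 3.3-fold lower number from compound 3 to compound 4 (0.52 log units; beyond the scatter) as the first direct step at this position. The confounded comparison of compound 3 with compound 1 and compound 2 therefore resolves in favour of the nitrogen: with hydrogen there, the aryl exchanges give a 1.5-fold higher number from compound 2 to compound 4 (0.19 log units; within the scatter) and a 1.1-fold lower number from compound 1 to compound 4 (0.03 log units; within the scatter) and leave phenyl, 3,4-dimethoxyphenyl and 4-chloro-3-(trifluoromethyl)phenyl unseparated. Among the steps in hand, only the one at the nitrogen lies beyond the scatter, and no measurement on hand accounts for its direction or size.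

Open, on these data alone, is whether a methyl on the nitrogen of compound 1 or compound 2 would raise the number as it does on the benzyl compound, and whether an ethyl group on that nitrogen would follow the methyl. Also open, as far as these compounds go, is what a longer chain between the two nitrogens, or an amide carbonyl in place of the saturated chain carbon bound to the amine nitrogen, would do.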